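This account rests on a few compounds, and the source may have more. Where it says the series, first, only, none or still open, it means among the compounds named here.

In an ADME assay on MDBK cells (Bos taurus) for cytotoxicity (on this read-out lower numbers stand for higher toxicity in this test and higher numbers for lower toxicity in this test), compound 1 `c1ccc(Cn2ccc3nc(-c4ccccc4)nc-3c2)cc1` gives > 100000 nM, which is a limit of the assay and not a number. Compound 2 `CCC(CC)Cn1ccc2nc(-c3ccccc3)nc-2c1` gives > 100000 nM, which is also a limit, so its position is known only as a limit. For the measured compounds named here, the one measured step, a step that the two limits leave unreadable from compound 1 to compound 2, therefore offers no size to carry forward, and the evidence amounts to the limit of > 100000 nM in this assay, at which 2 of the 2 values shown sit. Compound 3 `CC(C)N(CCn1ccc2nc(-c3ccccc3)nc-2c1)C(C)C` places (diisopropylamino)methyl in place of pentan-3-yl on a saturated chain carbon bound to an aromatic nitrogen. Going by the values given here, no measured step bears on this change in size, so the forecast for this assay is weakly held, and a further limit is quite possible. The expected step, an at least 1.2-fold lower number from compound 2 to compound 3 (0.09 log units; that floor lies within the scatter), is estimated to be modest and, if readable, towards lower numbers. For compound 3 the estimate is 80000 nM, with an expected range of 25000 nM to 100000 nM.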

Compound 3, half-maximal cytotoxic concentration: > 100000 nM
Compound 3: no number, only a limit (the forecaster's own chance of this, stated with the estimate: 55%); middle value at least 1.2-fold (0.09 log units) from the limit.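

In this assay compound 3 gives > 100000 nM, which is a limit and not a number. The steps to compound 3 from compound 1 and from compound 2 cannot be read. The compounds shown leave open at what concentration any of them becomes cytotoxic, and whether their groups differ in this test at all: the limit of > 100000 nM in this assay, at which 3 of the 3 values shown sit.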